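Furanyl chalcones with a halogen and a nitro group

A few compounds are considered here, and "the series" means these few. Any claim that something is new, unique, unknown or untested is made for them only; others in the source may bear on it.

Three furanyl chalcones have been tested in a functional assay on HeLa cells (Homo sapiens) for inhibition, read by MTT assay, with a stated time of 48 h; on this read-out lower numbers stand for stronger inhibition and higher numbers for weaker inhibition. Compound 3 `O=C(/C=C/c1ccccc1)c1ccco1` carries no substituent on its phenyl ring, and in this assay compound 3 gives only a limit of the assay, > 100000 nM. Compound 1 `O=C(/C=C/c1ccc(Cl)cc1)c1ccco1` differs from it by chloro in place of hydrogen on an aromatic carbon, and in this assay compound 1 gives 38000 nM; the step is an at least 2.6-fold lower number from compound 3 to compound 1 (0.42 log units; beyond the scatter). Compound 2 `O=C(/C=C/c1cccc([N+](=O)[O-])c1)c1ccco1` differs from compound 3 by nitro in place of hydrogen on an aromatic carbon, and in this assay compound 2 gives 22000 nM; going the other way, the step is an at least 4.5-fold higher number from compound 2 to compound 3 (0.65 log units; beyond the scatter). Both steps rest on (the limit of > 100000 nM in this assay, at which 1 of the 3 values shown sits), so their true size is not known. Compound 2 and compound 1 lie within the scatter of each other.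

Compound 4 `O=C(/C=C/c1cc([N+](=O)[O-])ccc1Cl)c1ccco1` is not yet measured. It differs from compound 2 by chloro in place of hydrogen on an aromatic carbon. The step from compound 3 to compound 1 is the same kind of change, but the place is not the same: there the chloro group stands para to a group of 9 heavy atoms, whereas in compound 4 it stands ortho to a group of 9 heavy atoms and para to a nitro group. Resting on the step of an at least 2.6-fold lower number from compound 3 to compound 1 (0.42 log units; beyond the scatter), compound 4 is expected to show a 1.5-fold lower number from compound 2 to compound 4 (0.17 log units; within the scatter). The value of compound 4 in this assay is estimated at 15000 nM, between 6000 nM and 45000 nM.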

Compound 4, half-maximal inhibitory concentration: > 100000 nM
Compound 4: a limit, no number; the forecaster's own chance of this, stated with the estimate: 5%; middle value at least 6.6-fold (0.82 log units) away from the limit.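

In this assay compound 4 gives > 100000 nM, which is a limit of the assay and not a number. Set against the earlier step, the new one, an at least 4.5-fold higher number from compound 2 to compound 4 (0.65 log units; beyond the scatter), runs the other way, so chloro in place of hydrogen on an aromatic carbon does not carry from one core to the other in this series: the same change on two cores in this assay, an at least 2.6-fold lower number (0.42 log units; beyond the scatter) from compound 3 to compound 1 and an at least 4.5-fold higher number (0.65 log units; beyond the scatter) from compound 2 to compound 4, at least 11-fold (1.07 log units) apart, beyond the scatter of two such steps It remains unsettled whether the nitro group or the place of the chloro group decides this; in compound 4 the chloro group stands ortho to a group of 9 heavy atoms and para to a nitro group, and the true size of either step is not known: the limit of > 100000 nM in this assay, at which 2 of the 4 values shown sit.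

The compounds shown leave open whether a chloro group placed as in compound 1, para to the group of 9 heavy atoms, would give a step in the same direction on the core of compound 2. Equally open, from the compounds shown here alone, is what a fluoro group, an amine, a carboxylic acid or a longer chain would give in place of the chloro group on that core.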